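Compound 3: A Shorter Heteroaryl Arm on the Shared Core

This account rests on a few compounds, and the source may have more. Where it says the series, first, only, none or still open, it means among the compounds named here.

Compound 2 `CCOC(=O)C1=C(C)NC(C)=C(C(=O)OCC)C1c1ccc(OCC(=O)NNC(=O)c2sccc2Cl)cc1` gives 10.6% in a functional assay on the whole organism (strain Wistar) for inhibition, with Rattus norvegicus as the target, read by paw edema, with stated times of 30 min and 0.5 h, at a dose of 20 mg/kg (on this read-out higher numbers stand for more inhibition at the one dose given (going by the name of the read-out) and lower numbers for less inhibition), the higher of the two numbers recorded, though the gap to compound 1 `CCOC(=O)C1=C(C)NC(C)=C(C(=O)OCC)C1c1ccc(OCC(=O)NNC(=O)c2ccccc2)cc1`, which gives 9.1%, is within the scatter: a number 1.5 percentage points higher from compound 1 to compound 2 (within the scatter). Compound 3 `CCOC(=O)C1=C(C)NC(C)=C(C(=O)OCC)C1c1ccc(OCc2nnc(S)o2)cc1` carries a group of 6 heavy atoms (2 carbon, 2 nitrogen, 1 oxygen, 1 sulfur; one five-membered aromatic ring with 3 hetero atoms) in place of a group of 12 heavy atoms (6 carbon, 2 nitrogen, 2 oxygen, 1 sulfur, 1 chlorine; one five-membered aromatic ring with 1 hetero atom), on a saturated chain carbon bound to an oxygen on an aromatic ring. Among the compounds with values here, the only measured step, that from compound 1 to compound 2, swapped an aryl group on a carbonyl carbon and stayed within the scatter, so it bears only loosely on this larger change. Compound 3 is therefore expected to show a number 0.6 percentage points lower from compound 2 to compound 3 (within the scatter). The value of compound 3 in this assay is estimated at 10%, ranging from 2% to 22%.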

Compound 3, a percentage reported as inhibition, in the whole organism at one dose (the size of the read-out at that dose, not a potency): 42.4%
Beside the measured number, compound 3's estimate is 32.4 percentage points below it; measured number above the stated range.
By their numbers in this assay, from the lowest: compounds 1 and 2 (each within the scatter of the next); then compound 3.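

At the saturated chain carbon bound to an oxygen on an aromatic ring, replacing the whole arm moves this assay far more than the earlier aryl swap on the carbonyl carbon did, with a number 31.8 percentage points higher from compound 2 to compound 3 (beyond the scatter) and a number 33.3 percentage points higher from compound 1 to compound 3 (beyond the scatter). The 5-sulfanyl-1,3,4-oxadiazol-2-yl group thus gives a large gain in this series, although it is the smaller of the two groups exchanged between compound 2 and compound 3. Nothing available explains this gain.

As far as these compounds go, it remains open whether the gain rests with the oxadiazole ring or with its sulfanyl group. An amine on that ring, or a carboxylic acid on the chain carbon, would bear on this.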